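The compounds below may be only part of what the source reports. "The series", "measured", "known", "first", "only" and "open" are said of these compounds alone.

In an assay on HEK293 cells for activation of Kir3.1/Kir3.2 (Homo sapiens), read by thallium flux (a higher number here means a larger maximal response, a lower number a smaller maximal response), the measured compounds are:
compound 1 `Cc1cc(NC(=O)Cn2nnc(-c3cc(Cl)cc(Cl)c3)n2)n(C2CCCCC2)n1` gives 82%.
Compound 2 `Cc1cc(NC(=O)Cn2nnc(-c3cccc(F)n3)n2)n(C2CCCCC2)n1` gives > 83%.

For compound 2 that figure is a limit of the assay and not a number, namely (the limit of > 83% in this assay, at which 1 of the 2 values shown sits). Compound 3 `Cc1cc(NC(=O)Cn2nnc(-c3cccc(C(F)(F)F)c3)n2)n(C2CCCCC2)n1` differs from compound 2 in one place: 3-(trifluoromethyl)phenyl in place of 6-fluoropyridin-2-yl on an aromatic carbon. Among the compounds with values here, the only measured step, a number at least 1 percentage points higher from compound 1 to compound 2 (that floor lies within the scatter), also swapped the aromatic group at this position and stayed within the scatter, so this position has so far tolerated such changes without a shift in the maximal response. No step beyond the scatter is expected here, with a step that the limit leaves unreadable from compound 2 to compound 3. Compound 3 is therefore estimated at 85%, with a range from 70% to 100%.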

Compound 3, largest response reached (Emax), in percent of the reference or control that the assay uses: 86%
Beside the measured number, compound 3's estimate is 1 percentage points below it, within the range that was stated.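

In this assay, 3-(trifluoromethyl)phenyl in place of 3,5-dichlorophenyl gives a number 4 percentage points higher from compound 1 to compound 3 (within the scatter). Within the data shown here, this is the first step at this position with a readable size, since the earlier one gave only a floor, and it shows that these two carbon-only aromatic rings are interchangeable here within the scatter. Compound 2 has a limit and not a number, so the steps that involve it cannot be sized: the limit of > 83% in this assay, at which 1 of the 3 values shown sits.

All the groups shown at this position are six-membered aromatic rings. Going by these compounds, whether an amine or a carboxylic acid would keep the maximal response here remains open.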